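The source may report more compounds than this note shows. Statements on the series, on what has been measured and on what is new or still open speak of the compounds shown alone.

Working notes on the series. Compound 1 `C=C/C=C\[C@H](C)[C@H](OC(N)=O)[C@@H](C)[C@H](O)CC/C=C\C(C)[C@@H](O)[C@@H](C)/C=C\CC[C@@H]1OC(=O)[C@H](C)[C@@H](O)[C@@H]1C` gives 7.5 nM in a functional assay on PC-3 cells (Homo sapiens) for inhibition; a lower number here means a stronger inhibitor of growth, a higher number a weaker inhibitor of growth. Compound 2 `COCOC1=C(C)C(=O)O[C@@H](CC/C=C\[C@H](C)[C@H](O)C(C)/C=C\CC[C@@H](O)[C@H](C)[C@@H](OC(N)=O)C(C)C)[C@@H]1C` reads > 50 nM in this assay, which is a limit and not a number. Compound 3 `CC1=C(O)O[C@@H](CC/C=C\[C@H](C)[C@H](O)C(C)/C=C\CC[C@@H](O)[C@H](C)[C@@H](OC(N)=O)C(C)C)[C@H](C)C1=O` reads > 50 nM, also a limit. Among the measured compounds shown here, the series so far therefore shows (the limit of > 50 nM in this assay, at which 2 of the 3 values shown sit), and compound 2 stands at that limit with no exact value.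

Compound 4 `COCOC1=C(C)C(=O)O[C@@H](CC/C=C\[C@H](C)[C@H](O)C(C)/C=C\CC[C@@H](O)[C@H](C)[C@@H](OC(N)=O)C(C)C)[C@H]1C` is compared with compound 2 as follows: the two compounds have the same atoms and bonds; at least one stereo element is drawn with a configuration in one of them and without one in the other: 1 of 10 stereo elements differ; a stereocentre at a saturated ring carbon is drawn S in compound 2 and R in compound 4. No atom or bond changes, so the comparison rests on that one stereocentre at a saturated ring carbon, drawn S in compound 2 and R in compound 4. For the measured compounds named here, no measured pair isolates such a change, so there is no direct guide to its size.

Compound 4 is expected to remain a weak inhibitor of growth because compound 2 gives > 50 nM. The expected step that the limit leaves unreadable from compound 2 to compound 4 is not expected to exceed the scatter in either direction. For compound 4 the estimated value is 80 nM, with an expected range of 50 nM to 300 nM.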

Compound 4, concentration for 50% growth inhibition: > 50 nM
Compound 4: a limit, no number; the forecaster's own chance of this, stated with the estimate: 75%; the middle value does not contradict the limit.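

In this assay, among the compounds shown here, compound 2 and compound 4 both stand at a limit and not at a number, so no step between them can be read: the limit of > 50 nM in this assay, at which 3 of the 4 values shown sit. The compounds shown leave open whether the configuration at that saturated ring carbon affects growth inhibition at all.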